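Swapping the aryl group on an alpha-keto oxazole FAAH inhibitor

The source may hold more compounds than are shown below. What is called first, only, known or untested is meant among the compounds shown, and "the series" means these compounds.

Measured compounds:
- compound 1, `O=C(CCCCCCc1ccccc1)c1ncc(-c2ccccc2F)o1`: 110 nM
- compound 2, `O=C(CCCCCCc1ccccc1)c1ncc(-c2cccc(O)c2)o1`: 50 nM
- compound 3, `Nc1ccc(-c2cnc(C(=O)CCCCCCc3ccccc3)o2)cc1`: 90 nM

These three share one core and differ only in the aromatic group attached to it. In an assay (Rattus norvegicus) for inhibition of Fatty-acid amide hydrolase 1 (Homo sapiens) (a lower number here means a stronger inhibitor, a higher number a weaker inhibitor), compound 1 gives the highest of the three numbers. Its nearest neighbour is compound 3, reached by a 1.2-fold lower number from compound 1 to compound 3 (0.09 log units; within the scatter). Further off stands compound 2, reached by a 2.2-fold lower number from compound 1 to compound 2 (0.34 log units; beyond the scatter).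

The new compound 4, `O=C(O)c1ccc(-c2cnc(C(=O)CCCCCCc3ccccc3)o2)cc1`, has not yet been measured. It differs from compound 1 in one place: 4-carboxyphenyl in place of 2-fluorophenyl on an aromatic carbon. The two measured steps away from compound 1 both put a group bearing a hydrogen-bond donor on the aromatic ring and both gave a lower number, one modestly and one within the scatter. For the measured compounds named here, a carboxyl group, however, is not represented among the measured compounds, so no step speaks to it directly.

Compound 4 is therefore expected to lie near compound 1, with a step of a 1.8-fold higher number from compound 1 to compound 4 (0.26 log units; within the scatter) and a wide range. The estimate for compound 4 is 200 nM, between 60 nM and 700 nM.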

Compound 4, inhibition constant: 60 nM
The estimate for compound 4 lay 3.3-fold (0.52 log units) above the measured number; low and high end bracket the measured number.
By their numbers in this assay, from the lowest: compounds 2, 4, 3 and 1 (each within the scatter of the next, the first and the last beyond it).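

In this assay, a carboxyl group, new to this set, proves compatible with this place on the shared core: the step to 4-carboxyphenyl stays within the scatter (a 1.8-fold lower number from compound 1 to compound 4 (0.26 log units; within the scatter)). Compound 4 also cannot be told apart from the amino or the hydroxy compound (a 1.5-fold lower number from compound 3 to compound 4 (0.18 log units; within the scatter); a 1.2-fold higher number from compound 2 to compound 4 (0.08 log units; within the scatter)), so it fits alongside all three earlier groups, even though compound 1 and compound 2 differ beyond the scatter. No measurement here offers a reason why such different groups give such close numbers.

The compounds shown leave open whether a methyl ester in place of the carboxylic acid, or a plain phenyl with no added group, would stay in this range. They also do not show whether 3-carboxyphenyl would match 4-carboxyphenyl.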